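A few compounds are considered here, and "the series" means these few. Any claim that something is new, unique, unknown or untested is made for them only; others in the source may bear on it.

Compound 1, `C/C(=N\O)c1ccc(NC(=O)Cn2nc(-c3ccc(Cl)cc3)nc2N)cc1`, gives 10.5% in a functional assay on SF-268 cells (Homo sapiens) for inhibition, read by sulforhodamine B assay, with a stated time of 48 h, tested at 10 uM; a lower number here means less inhibition of growth, a higher number more inhibition of growth at the concentration tested.
Compound 2, `COc1cc(-c2nc(N)n(CC(=O)Nc3ccc(/C(C)=N\O)cc3)n2)cc(OC)c1OC`, gives 6.49% in this assay.
Compound 3, `c1ccc(-c2nc3sc(-c4ccccc4)cn3n2)cc1`, gives 7% in this assay.

All three measured numbers are low, and none of them is separated from another by more than the usual scatter of this assay. Compound 3 is no exception: its value sits close to that of compound 2 and only a little further from that of compound 1, both gaps being within the scatter, so the three compounds cannot be told apart on these numbers.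

Compound 4, `Clc1ccc(-c2cn3nc(-c4ccccc4)nc3s2)cc1`, differs from compound 3 in one place: chloro in place of hydrogen on an aromatic carbon. Among the compounds with values here, no measured pair shows what this change does in this assay, so there is nothing to set the size of the step on. Since every measured compound, whatever its core, lands in the same low band, the expectation is that compound 4 stays there too, with the step from compound 3 estimated at a number 2 percentage points higher from compound 3 to compound 4 (within the scatter), not beyond the scatter in either direction. Compound 4 is therefore expected to give about 9%, most likely between 2% and 20%.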

Compound 4, percent growth inhibition at one concentration: 20%
The estimate for compound 4 lay 11 percentage points below the measured number, within the range that was stated.
By their numbers in this assay, from the lowest: compounds 2, 3, 1 and 4 (each within the scatter of the next, the first and the last beyond it).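

Turning phenyl into 4-chlorophenyl, with chloro in place of hydrogen on an aromatic carbon, gives a number 13 percentage points higher from compound 3 to compound 4 (beyond the scatter) in this assay. Within the data shown here, this is the first step in the set that can be read, and it shows that this place on the ring is not indifferent: one chlorine atom is enough to change the number by more than the usual scatter, although the step is modest and rests on a single pair. Nothing measured here accounts for why the number moves with this change.

As far as these compounds go, it remains open whether other groups in the same place, such as bromo, an amine or a carboxylic acid, would raise the number further, leave it unchanged or lower it. Also open, from the compounds shown here alone, is whether chloro would give a step of similar size on a different core.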